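A Chlorine Added to an Amide-Capped Core

This account rests on a few compounds, and the source may have more. Where it says the series, first, only, none or still open, it means among the compounds named here.

Compound 1 `Cc1cc(-c2nc3cc(Cl)ccc3o2)ccc1NC(=O)CN1CCN(CCCN(C)C)CC1` and compound 2 `Cc1cc(-c2nc3ccccc3o2)ccc1NC(=O)CN1CCN(CCCN(C)C)CC1` share one core and differ in a single place: compound 1 carries chloro in place of hydrogen on an aromatic carbon. In a functional assay on A549 cells (Homo sapiens) for cytotoxicity, read by MTT assay, with a stated time of 24 h (on this read-out lower numbers stand for stronger inhibition and higher numbers for weaker inhibition), compound 1 gives 10500 nM, and compound 2 gives 22100 nM; the step is a 2.1-fold lower number from compound 2 to compound 1 (0.32 log units; beyond the scatter). Compound 3 `Cc1cc(-c2nc3ccccc3o2)ccc1NC(=O)CCl` has a different core, and the difference between the two cores is not broken down here; in this assay compound 3 gives 33500 nM. Compound 4 `Cc1cc(-c2nc3cc(Cl)ccc3o2)ccc1NC(=O)CCl`, not yet measured, repeats the same change on compound 3: chloro in place of hydrogen on an aromatic carbon. Because that change produced a 2.1-fold lower number from compound 2 to compound 1 (0.32 log units; beyond the scatter), a step of similar size is expected here, a 2.1-fold lower number from compound 3 to compound 4 (0.32 log units; beyond the scatter), although this rests on a single measured pair. Compound 4 is therefore estimated at 16000 nM, expected to lie between 8000 nM and 35000 nM.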

Compound 4, half-maximal inhibitory concentration: 91500 nM
Estimate against measurement, compound 4: 5.7-fold (0.76 log units) below; the measured number lies above the stated range.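

On a second core, the same swap of hydrogen for chloro on an aromatic carbon gave a 2.7-fold higher number from compound 3 to compound 4 (0.44 log units; beyond the scatter) in this assay, so the number moved the opposite way from the first pair. The change therefore did not carry over from one core to the other, in either direction or size: the same change on two cores in this assay, a 2.1-fold lower number (0.32 log units; beyond the scatter) from compound 2 to compound 1 and a 2.7-fold higher number (0.44 log units; beyond the scatter) from compound 3 to compound 4, 5.7-fold (0.76 log units) apart, beyond the scatter of two such steps This shows that the outcome of adding this chloro depended on the core in these two pairs, but two pairs set no general rule and do not show why the steps differ.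

From the compounds shown here alone, it remains open whether a bromine atom or a methoxy group on the same aromatic carbon would also behave differently on the two cores. Going by these compounds, it is also open which result a core carrying a morpholine on the amide chain would follow.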